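The compounds below may be only part of what the source reports. "The series", "measured", "known", "first", "only" and "open" are said of these compounds alone.

Measured compounds:
compound 1 `CC(=O)Nc1ccc(S(=O)(=O)NNc2ccc(S(N)(=O)=O)cc2)cc1`, 2480 nM in an assay for inhibition of Indoleamine 2,3-dioxygenase 1 (Homo sapiens), read by spectrophotometry, with stated times of 1 h and 4 h; a lower number here means a stronger inhibitor, a higher number a weaker inhibitor
compound 2 `CC(=O)Nc1ccc(S(=O)(=O)NNc2ccc(C(F)(F)F)cc2)cc1`, 1610 nM
compound 3 `CC(=O)Nc1ccc(S(=O)(=O)NNc2ccc(Br)cc2)cc1`, 130 nM

Compound 3 gives the lowest number of the three. The steps from compound 1 to compound 3 (a 19-fold lower number from compound 1 to compound 3 (1.28 log units; beyond the scatter)) and from compound 2 to compound 3 (a 12-fold lower number from compound 2 to compound 3 (1.09 log units; beyond the scatter)) are both large, while the step from compound 1 to compound 2 (a 1.5-fold lower number from compound 1 to compound 2 (0.19 log units; within the scatter)) is within the scatter. Compound 4 `COC(=O)CCc1ccc(S(=O)(=O)NNc2ccc(Br)cc2)cc1` keeps the bromo-bearing ring of compound 3 and changes the other ring: 2-(methoxycarbonyl)ethyl in place of acetamido on an aromatic carbon. Among the measured compounds shown here, none of the measured steps touches this position; all three vary the group on the opposite ring. For the measured compounds named here, no measured step therefore bears on this change, and its direction cannot be read from the data. Compound 4 is expected to stay near compound 3, a step of a 1.5-fold higher number from compound 3 to compound 4 (0.19 log units; within the scatter), giving an estimate of 200 nM with a range from 50 nM to 800 nM.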

Compound 4, half-maximal inhibitory concentration: 121 nM
Estimate against measurement, compound 4: 1.7-fold (0.22 log units) above, and the stated range covers the measured number.
By their numbers in this assay, from the lowest: compounds 4 and 3 (each within the scatter of the next); then compounds 2 and 1 (each within the scatter of the next).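

With the bromo group held fixed, this position now has a measured step: 2-(methoxycarbonyl)ethyl in place of acetamido gives a 1.1-fold lower number from compound 3 to compound 4 (0.03 log units; within the scatter). The entering group has 0 hydrogen-bond donors where acetamido has 1, and it is the larger by heavy atoms, yet the number stays within the scatter. Nothing at hand explains this result. From the compounds shown here alone, whether a carboxylic acid, an amine or a longer chain would be tolerated here stays open. So does whether 2-(methoxycarbonyl)ethyl would give a similar step with trifluoromethyl or sulfamoyl in place of bromo.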